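A few compounds are considered here, and "the series" means these few. Any claim that something is new, unique, unknown or untested is made for them only; others in the source may bear on it.

Working notes on the series. Compound 1 `FC(F)(F)c1cc(COCC2(c3ccccc3)CCC(N3CCCCC3)CC2)cc(C(F)(F)F)c1` gives 93 nM in an assay on isolated protein for antagonist activity at Substance-P receptor (Homo sapiens); on this read-out higher numbers stand for weaker inhibition and lower numbers for stronger inhibition. Compound 2 `CN1CCN(C2CCC(COCc3cc(C(F)(F)F)cc(C(F)(F)F)c3)(c3ccccc3)CC2)CC1` gives 120 nM in this assay. On the two numbers shown compound 2 stands as close to compound 1 as the scatter allows: a 1.3-fold higher number from compound 1 to compound 2 (0.11 log units; within the scatter). The two amines on the saturated ring carbon thus give indistinguishable numbers.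

Next comes compound 3 `FC(F)(F)c1cc(COCC2(c3ccccc3)CCC(NC3CC3)CC2)cc(C(F)(F)F)c1`, not yet measured. The change from compound 2: cyclopropylamino in place of 4-methylpiperazin-1-yl on a saturated ring carbon. Within the data shown here, the one measured step bears on it, as it also exchanged the amine on the same saturated ring carbon, and it was a 1.3-fold higher number from compound 1 to compound 2 (0.11 log units; within the scatter), within the scatter. A further amine exchange at that position is therefore expected to give no step beyond the scatter in this assay, and the expected step is a 1.2-fold lower number from compound 2 to compound 3 (0.08 log units; within the scatter). Compound 3 is accordingly estimated at 100 nM in this assay, with a range from 35 nM to 300 nM.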

Compound 3, half-maximal inhibitory concentration: 74 nM
Compound 3: the middle estimate sits 1.4-fold (0.13 log units) above what was measured; the measured number falls inside the stated range.
By their numbers in this assay, from the lowest: compounds 3, 1 and 2 (each within the scatter of the next).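

In this assay, replacing 4-methylpiperazin-1-yl with the smaller cyclopropylamino, which also brings a hydrogen-bond donor, gives a 1.6-fold lower number from compound 2 to compound 3 (0.21 log units; within the scatter). Replacing piperidin-1-yl with cyclopropylamino gives a 1.3-fold lower number from compound 1 to compound 3 (0.10 log units; within the scatter), so the three amines on this saturated ring carbon, which now include a three-membered carbon ring as well as two six-membered rings, cannot be told apart on these numbers. No independent measurement accompanies these values to account for this result.

The compounds shown leave open whether a group with no amine nitrogen at this position, such as a hydroxyl or a carboxylic acid, would stay within the scatter of these three. They also leave open what a longer chain on the amine nitrogen, such as n-hexyl in place of cyclopropyl, would give in this assay.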